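Ethyl in place of the urea hydrogen of compound 2

The compounds below may be only part of what the source reports. "The series", "measured", "known", "first", "only" and "open" are said of these compounds alone.

Two members of the series have been run in a functional assay on MCF7 cells (Homo sapiens) for cytotoxicity, read by MTT assay, with a stated time of 72 h (on this read-out lower numbers stand for stronger inhibition and higher numbers for weaker inhibition), so far, and neither gave a number. Compound 1 `CCNC(=O)N1CCN(C(=S)SCc2cn(Cc3ccc(Cl)cc3)nn2)CC1` in this assay gives only a limit, > 128000 nM. Compound 2 `COc1cc(Cn2cc(CSC(=S)N3CCN(C(N)=O)CC3)nn2)cc(OC)c1OC` in this assay likewise gives only a limit, > 128000 nM. Compound 2 therefore stands at the edge of what this assay reports, with no measured value to rank it. Both results sit at the limit of > 128000 nM in this assay, at which 2 of the 2 values shown sit. Compound 3 `CCNC(=O)N1CCN(C(=S)SCc2cn(Cc3cc(OC)c(OC)c(OC)c3)nn2)CC1` is not yet measured; it differs from compound 2 by ethyl in place of hydrogen on an amide-type nitrogen. The same ethylcarbamoyl end is already present in compound 1, which also returned only a limit. Within the data shown here, no measured step is available for this change, and no shift beyond the scatter is expected from compound 2 to compound 3 in this assay, with a step that the limit leaves unreadable from compound 2 to compound 3 as the expected step. Compound 3 is estimated at 160000 nM, between 60000 nM and 500000 nM, most probably reported again as a limit.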

Compound 3, half-maximal inhibitory concentration: > 128000 nM
Compound 3 ended at the assay's limit; the forecaster's own chance of this, stated with the estimate: 85%; the middle value does not contradict the limit.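

Compound 2 and compound 3 give no readable step for ethyl in place of hydrogen on the amide-type nitrogen, and both results are only limits: the limit of > 128000 nM in this assay, at which 3 of the 3 values shown sit.

The compounds shown leave open whether this change, or any other difference among them, shifts the read-out at all.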